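Para substituent on the benzamide ring: methyl after trifluoromethyl

This account rests on a few compounds, and the source may have more. Where it says the series, first, only, none or still open, it means among the compounds named here.

Measured so far in an assay on V79 cells for inhibition of cytochrome P450 11B2, mitochondrial (Homo sapiens), tested at 500 nM; on this read-out higher numbers stand for more inhibition at the one concentration tested (going by the name of the read-out) and lower numbers for less inhibition:
compound 1 `O=C(Nc1cccnc1)c1ccccc1` gives 30%
compound 2 `O=C(Nc1cccnc1)c1ccc(Cl)cc1` gives 88%
compound 3 `O=C(Nc1cccnc1)c1ccc(C(F)(F)F)cc1` gives 1%

Compound 3 is the lowest of the three numbers: compound 1 stands a number 29 percentage points lower from compound 1 to compound 3 (beyond the scatter) and compound 2 stands a number 87 percentage points lower from compound 2 to compound 3 (beyond the scatter) from it, both beyond the scatter. Compound 4 `Cc1ccc(C(=O)Nc2cccnc2)cc1` differs from compound 3 in one place: methyl in place of trifluoromethyl on an aromatic carbon.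

Going by the values given here, two measured steps bear on this change, since both replace trifluoromethyl on that aromatic carbon. The step to hydrogen, read backwards from a number 29 percentage points lower from compound 1 to compound 3 (beyond the scatter), recovers a modest amount; the step to chloro, read backwards from a number 87 percentage points lower from compound 2 to compound 3 (beyond the scatter), recovers a large amount. Methyl is neither hydrogen nor chloro, so no measured step gives it directly, and the size of the rise is uncertain in this assay. A rise beyond the scatter is expected, most likely between the two measured recoveries.

Compound 4 is therefore estimated at 50%, in the range 15% to 85%, which means an expected step of a number 49 percentage points higher from compound 3 to compound 4 (beyond the scatter).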

Compound 4, a percentage reported as inhibition, at one concentration (the size of the read-out at that concentration, not a potency): 25%
For compound 4 the middle estimate is 25 percentage points above the measured one; measured number inside the range.
By their numbers in this assay, from the lowest: compound 3; then compounds 4 and 1 (each within the scatter of the next); then compound 2.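

In this assay, methyl on this aromatic carbon does not separate from hydrogen, with a number 5 percentage points lower from compound 1 to compound 4 (within the scatter), so adding this one carbon leaves the number within the scatter of the unsubstituted compound. It still stands clear of trifluoromethyl, with a number 24 percentage points higher from compound 3 to compound 4 (beyond the scatter), but falls far short of chloro, with a number 63 percentage points lower from compound 2 to compound 4 (beyond the scatter), so among the four groups shown only chloro lifts the number beyond the scatter of hydrogen. Nothing measured here accounts for the gap between chloro and methyl.

Open, going by these compounds, is whether fluoro or bromo would follow chloro, or whether a methoxy group, a nitrile or an amine on this carbon would also rise clear of hydrogen. Also open, on these data alone, is whether the chloro gain would hold with a change elsewhere on the shared core.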